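The compounds below may be only part of what the source reports. "The series", "measured", "known", "first", "only" and "open" are said of these compounds alone.

Compound 3, `OB1OCc2ccc(-n3cccc3)cc21`, is the smallest member of this set. In an ADME assay on L929 cells (Mus musculus) for cytotoxicity, read by resazurin assay, with a stated time of 72 h (on this read-out lower numbers stand for stronger inhibition and higher numbers for weaker inhibition), compound 3 gives > 10 ug/mL, which is a limit of the assay rather than a number. Compound 1, `OB1OCc2ccc(-n3cc(Sc4ccc(Cl)cc4)c4ccccc43)cc21`, also reaches only a limit: in this assay compound 1 gives > 10 ug/mL. Compound 2, `OB1OCc2ccc(-n3cc(Sc4ccccc4O)c4ccccc43)cc21`, likewise stops at a limit, giving > 10 ug/mL in this assay. Going by the values given here, the step that the two limits leave unreadable from compound 1 to compound 2 therefore cannot be sized, and the only evidence is the limit of > 10 ug/mL in this assay, at which 3 of the 3 values shown sit. Compound 4, `CCCNC(=O)c1cccn1-c1ccc2c(c1)B(O)OC2`, differs from compound 3 by propylcarbamoyl in place of hydrogen on an aromatic carbon. Among the compounds with values here, no measured step bears directly on this change, so no shift beyond the scatter is expected, and the expected step that the limit leaves unreadable from compound 3 to compound 4 is near zero. Compound 4 is therefore estimated at 20 ug/mL, within a range from 8 ug/mL to 50 ug/mL.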

Compound 4, half-maximal inhibitory concentration: > 10 ug/mL
Compound 4 ended at the assay's limit (the forecaster's own chance of this, stated with the estimate: 80%); the middle value does not contradict the limit.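

The step from compound 3 to compound 4 cannot be sized, because both compounds stop at a limit of the assay, as do the others: the limit of > 10 ug/mL in this assay, at which 4 of the 4 values shown sit.

The compounds shown leave open how strongly any of them acts in this assay, and so how much any single change matters.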